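The source may report more compounds than this note shows. Statements on the series, on what has been measured and on what is new or still open speak of the compounds shown alone.

In an ADME assay on HEL cells (Homo sapiens) for cytotoxicity, with a stated time of 3 days (on this read-out lower numbers stand for higher toxicity in this test and higher numbers for lower toxicity in this test), compound 1, with the structure `O=S1(=O)C=C(OCc2ccccc2)C(Cc2ccccc2)(Cc2ccccc2)O1`, gives 200000 nM. Compound 2, `CCC1(CC)OS(=O)(=O)C=C1OCc1ccccc1`, reaches only a limit of the assay there, > 400000 nM. Compound 3, `CCC1(Cc2ccccc2)OS(=O)(=O)C=C1OCc1ccc(Cl)cc1`, likewise shows only a limit in this assay, >= 50000 nM. So compound 3 stands on a limit rather than a number, and it is not alone in that: of the three values shown, one sits at the limit of > 400000 nM in this assay, at which 1 of the 3 values shown sits, and one at the limit of >= 50000 nM in this assay, at which 1 of the 3 values shown sits, while compound 1 alone gives a measured number.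

The unmeasured compound 4, `CCC1(Cc2ccccc2)OS(=O)(=O)C=C1OCC=C(C)C`, differs from compound 3 in one place: 2-methylprop-1-en-1-yl in place of 4-chlorophenyl on a saturated chain carbon bound to an oxygen on an unsaturated carbon. For the measured compounds named here, no measured pair in this set is separated by such a change, so the expected size of the step in this assay rests on the picture of the three compounds alone, all of which sit at weak cytotoxicity. The author expects the step that the limit leaves unreadable from compound 3 to compound 4 to be small, not clearly beyond the scatter, with a real chance that compound 4 again returns only a limit. Compound 4 is therefore estimated at about 100000 nM in this assay, with a range from 30000 nM to 400000 nM.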

Compound 4, minimum cytotoxic concentration: 400000 nM
For compound 4 the middle estimate is 4.0-fold (0.60 log units) below the measured one; measured number inside the range.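

In this assay compound 3 gives >= 50000 nM as a limit and not a number, so the size of the change from compound 3 to compound 4 cannot be read. The compounds shown leave open how far 2-methylprop-1-en-1-yl in place of 4-chlorophenyl shifts the minimum cytotoxic concentration, as no pair with two measured numbers shows this change.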